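Benzyl amide on a shared core for alpha3/beta4 binding

The source may report more compounds than this note shows. Statements on the series, on what has been measured and on what is new or still open speak of the compounds shown alone.

Measured compounds:
compound 1 `COc1cc(NC(=O)c2cncc(N3CC4CC(C3)N4)c2)cc(OC)c1` — 2000 nM
compound 2 `COc1ccc(NC(=O)c2cncc(N3CC4CC(C3)N4)c2)cc1OC` — 516 nM
compound 3 `O=C(Nc1ccc(F)cc1)c1cncc(N2CC3CC(C2)N3)c1` — 81 nM

Of the compounds shown here, three on a shared core have been tested in an assay on cells for displacement of a labelled ligand from Neuronal acetylcholine receptor; alpha3/beta4 (Homo sapiens); a higher number here means a weaker inhibitor, a lower number a stronger inhibitor. Compound 1 gives 2000 nM, compound 2 gives 516 nM, and compound 3 gives 81 nM. Compound 3 stands lowest of the three; its nearest neighbour is compound 2, and both gaps, to compound 2 and to compound 1, lie beyond the scatter, so compound 3 is the strongest of the measured set.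

Compound 4 `O=C(NCc1ccccc1)c1cncc(N2CC3CC(C2)N3)c1` has not yet been measured. It departs from compound 3 by one change: benzyl in place of 4-fluorophenyl on an amide-type nitrogen. For the measured compounds named here, no pair of measured compounds shows this kind of change, so the size and direction of the step in this assay cannot be read from the existing numbers.

The author expects compound 4 to bind somewhat more weakly than compound 3, with the estimated step of a 2.5-fold higher number from compound 3 to compound 4 (0.39 log units; beyond the scatter) modest and uncertain in direction. The estimate for compound 4 in this assay is 200 nM, with a range from 40 nM to 1000 nM.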

Compound 4, inhibition constant: 1600 nM
Compound 4: middle estimate off by 8.0-fold (0.90 log units), on the low side; the measured number lies above the stated range.
By their numbers in this assay, from the lowest: compound 3; then compound 2; then compounds 4 and 1 (each within the scatter of the next).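

Benzyl in place of 4-fluorophenyl on an amide-type nitrogen gives in this assay a large loss of binding, a 20-fold higher number from compound 3 to compound 4 (1.30 log units; beyond the scatter), and this is the only step in the set that can be read at this position. It shows that this position is sensitive to the group it carries: the two groups have the same count of heavy atoms, and each holds one six-membered aromatic ring of carbon only, yet they lie far apart. Nothing available explains the size of this step.

The compounds shown leave open whether the loss goes with the benzyl group as a whole or with the absence of fluorine, which plain phenyl or 4-fluorobenzyl on the same nitrogen could help to separate. On these data alone, how a longer chain such as 2-phenylethyl would read at this position also remains open.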